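The source may hold more compounds than are shown below. What is called first, only, known or untested is meant among the compounds shown, and "the series" means these compounds.

For the measured compounds named here, compound 2 `CN1CCCCC1CNc1nc2c(c(Nc3ccc(C(F)(F)F)cc3)n1)CCN(c1ncccc1C(F)(F)F)CC2` was tested in a functional assay on HEK293 cells for antagonist activity at transient receptor potential cation channel subfamily V member 1 (Homo sapiens), read by FLIPR and calcium flux (a lower number here means a stronger inhibitor, a higher number a weaker inhibitor), and gives 1760 nM, the lowest of the two numbers measured so far. Going by the values given here, its only neighbour is compound 1 `CN(c1nc2c(c(Nc3ccc(C(F)(F)F)cc3)n1)CCN(c1ncccc1C(F)(F)F)CC2)C1CCCNC1`, which in this assay gives 3600 nM. The two differ only in the group on the same aromatic carbon of the shared core, and the measured step there is a 2.0-fold lower number from compound 1 to compound 2 (0.31 log units; beyond the scatter).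

Compound 3 `CC(=O)NC1CCN(c2nc3c(c(Nc4ccc(C(F)(F)F)cc4)n2)CCN(c2ncccc2C(F)(F)F)CC3)C1` carries a different group at that same place: 3-acetamidopyrrolidin-1-yl in place of ((1-methylpiperidin-2-yl)methyl)amino on an aromatic carbon. Among the compounds with values here, neither measured compound has this group, so the only guide is the one step at this position, which was modest. On that basis the change is expected to move the number by a modest amount, with the direction open. The expected step is estimated as a 1.7-fold higher number from compound 2 to compound 3 (0.23 log units; within the scatter), a slight loss chosen because compound 2 gives 1760 nM and so already holds the lower of the two measured numbers. For compound 3 the estimate in this assay is 3000 nM, within a range from 800 nM to 12000 nM.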

Compound 3, half-maximal inhibitory concentration: 150 nM
The estimate for compound 3 lay 20-fold (1.30 log units) above the measured number, and the stated range ends above it.
By their numbers in this assay, from the lowest: compound 3; then compound 2; then compound 1.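

In this assay this position proves far more sensitive than the first pair suggested: 3-acetamidopyrrolidin-1-yl in place of ((1-methylpiperidin-2-yl)methyl)amino gives a 12-fold lower number from compound 2 to compound 3 (1.07 log units; beyond the scatter) on the aromatic carbon, and in place of methyl(piperidin-3-yl)amino it gives a 24-fold lower number from compound 1 to compound 3 (1.38 log units; beyond the scatter) at that same carbon. For the compounds shown here, both steps are large, whereas the only earlier step was modest. The entering group has the same counts of heavy atoms, hydrogen-bond donors and hydrogen-bond acceptors as ((1-methylpiperidin-2-yl)methyl)amino, so those counts do not separate compound 2 from compound 3, and nothing measured here says why the number falls so far.

From the compounds shown here alone, it remains open whether the step belongs to the acetamido group or to the five-membered ring. A 3-aminopyrrolidin-1-yl group, with a free amine in place of the acetamide, would help to separate the two.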